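Methoxy on the phenyl: does compound 4 lose activity too?

A few compounds are considered here, and "the series" means these few. Any claim that something is new, unique, unknown or untested is made for them only; others in the source may bear on it.

Compound 1 `O=C(Nc1nc2ccccc2s1)c1cn(-c2ccccc2)nc1-c1ccccc1` is the parent of this small set. In a functional assay on A549 cells (Homo sapiens) for cytotoxicity, read by MTT assay, with a stated time of 72 h (on this read-out lower numbers stand for stronger inhibition and higher numbers for weaker inhibition), compound 1 gives 13500 nM, the highest of the two numbers measured; compound 2 `O=C(Nc1nc2ccc(F)cc2s1)c1cn(-c2ccccc2)nc1-c1ccccc1` gives 10200 nM, a step of a 1.3-fold lower number from compound 1 to compound 2 (0.12 log units; within the scatter). Compound 3 `COc1ccc2nc(NC(=O)c3cn(-c4ccccc4)nc3-c3ccccc3)sc2c1` reaches only a limit of the assay, > 50000 nM. Compound 4 `COc1ccc(-c2nn(-c3ccccc3)cc2C(=O)Nc2nc3ccccc3s2)cc1` differs from compound 1 by methoxy in place of hydrogen on an aromatic carbon. For the measured compounds named here, the one measured step with a methoxy entering at an aromatic carbon, though elsewhere on the core, is an at least 3.7-fold higher number from compound 1 to compound 3 (0.56 log units; beyond the scatter), a weakening. A similar but uncertain shift is therefore expected here, a 1.9-fold higher number from compound 1 to compound 4 (0.27 log units; within the scatter). Compound 4 is thus estimated at 25000 nM, within 8000 nM to 60000 nM, with a real chance of only a limit.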

Compound 4, half-maximal inhibitory concentration: 13700 nM
The estimate for compound 4 lay 1.8-fold (0.26 log units) above the measured number; measured number inside the range.
By their numbers in this assay, from the lowest: compounds 2, 1 and 4 (each within the scatter of the next). At a limit, above all of these: compound 3.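

In this assay, going from phenyl to 4-methoxyphenyl gives a 1.0-fold higher number from compound 1 to compound 4 (0.01 log units; within the scatter), so this position accepts a methoxy without a shift that can be told from the scatter. The same swap of hydrogen for methoxy therefore does not have one outcome on this core: its result depends on which ring carbon carries it. Compound 3, with its methoxy elsewhere on the core, alone stands at a limit: the limit of > 50000 nM in this assay, at which 1 of the 4 values shown sits.

Going by these compounds, what an amine, a carboxylic acid or a longer chain such as butoxy would do at this position stays open.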